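The source may report more compounds than this note shows. Statements on the series, on what has been measured and on what is new or still open speak of the compounds shown alone.

Measured so far, in a functional assay on SK-N-SH cells (Homo sapiens) for inhibition, read by MTT assay, with a stated time of 72 h, tested at 50 uM; a lower number here means less inhibition of growth, a higher number more inhibition of growth at the concentration tested:
Compound 1 `C=CCc1ccc(OCc2cn(-c3ccccc3CO)nn2)c(O)c1` gives 87.1%.
Compound 2 `C=CCc1ccc(OCc2cn(-c3cccc(C#N)c3)nn2)c(O)c1` gives 78.8%.
Compound 3 `C=CCc1ccc(OCc2cn(-c3cccc([N+](=O)[O-])c3)nn2)c(O)c1` gives 68.9%.

Compound 2 stands second highest of these three numbers. Its nearest neighbour is compound 1, and the step of a number 8.3 percentage points lower from compound 1 to compound 2 (within the scatter) lies within the scatter; compound 3 is the furthest away, and the step of a number 9.9 percentage points lower from compound 2 to compound 3 (within the scatter) also lies within the scatter. So the three compounds cannot be told apart with confidence.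

Compound 4 `C=CCc1ccc(OCc2cn(-c3ccc(OC)cc3)nn2)c(O)c1` differs from compound 2 in one place: 4-methoxyphenyl in place of 3-cyanophenyl on an aromatic nitrogen

For the measured compounds named here, two measured steps bear on this change. The step from compound 1 to compound 2 also swaps the whole group on that aromatic nitrogen, and the step from compound 2 to compound 3 changes a substituent on that ring; both stayed within the scatter. No step beyond the scatter is therefore expected in this assay, in either direction. The step of a number 2.8 percentage points lower from compound 2 to compound 4 (within the scatter) is expected to remain within the scatter. Compound 4 is estimated to give 76%, with a range from 62% to 88%.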

Compound 4, percent growth inhibition at one concentration: 68.5%
Compound 4: the middle estimate sits 7.5 percentage points above what was measured, within the range that was stated.
By their numbers in this assay, from the lowest: compounds 4, 3, 2 and 1 (each within the scatter of the next, the first and the last beyond it).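

For the compounds shown here, the change from 3-cyanophenyl to 4-methoxyphenyl gives a number 10.3 percentage points lower from compound 2 to compound 4 (beyond the scatter) in this assay and is the first single swap on this aromatic nitrogen to go beyond the scatter. Replacing 2-(hydroxymethyl)phenyl with 4-methoxyphenyl likewise gives a number 18.6 percentage points lower from compound 1 to compound 4 (beyond the scatter), so the choice of group at this position can move the number in this assay, although both steps are modest. No measurement available here explains either step.

The names 3-cyanophenyl and 4-methoxyphenyl differ in both the substituent and its number on the ring, so 3-methoxyphenyl would be needed to separate those two changes. On these data alone, how an amine or a carboxylic acid on this ring, or a longer chain in place of the ring, would read in this assay also remains open.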